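Ring Expansion on the Amide Nitrogen: Cyclohexyl to Cycloheptyl

The source may report more compounds than this note shows. Statements on the series, on what has been measured and on what is new or still open speak of the compounds shown alone.

Compound 1 `CC(C)(C)C(=O)N(CCCCCCN1C[C@H](O)[C@@H](O)[C@H](O)[C@H]1CO)C1CCCCC1` was tested in an ADME assay on BHK cells (Mesocricetus auratus) for cytotoxicity, read by MTT assay; on this read-out lower numbers stand for higher toxicity in this test and higher numbers for lower toxicity in this test. In this assay compound 1 gives > 500000 nM, which is a limit of the assay and not a number. Compound 2 `CC(C)(C)C(=O)N(CCCCCCN1C[C@H](O)[C@@H](O)[C@H](O)[C@H]1CO)c1cc(F)ccc1F` gives > 500000 nM, also a limit. Compound 3 `CC(C)(C)C(=O)N(CCCCCCN1C[C@H](O)[C@@H](O)[C@H](O)[C@H]1CO)C1CCCC1` gives > 500000 nM, again a limit. All three values sit at the limit of > 500000 nM in this assay, at which 3 of the 3 values shown sit. The steps a step that the two limits leave unreadable from compound 1 to compound 2 and a step that the two limits leave unreadable from compound 1 to compound 3 are therefore unreadable in size, as is a step that the two limits leave unreadable from compound 2 to compound 3. The change to compound 4 `CC(C)(C)C(=O)N(CCCCCCN1C[C@H](O)[C@@H](O)[C@H](O)[C@H]1CO)C1CCCCCC1` is cycloheptyl in place of cyclohexyl on an amide-type nitrogen. For the measured compounds named here, no measured step yields a readable size, so no step beyond the scatter is expected here. The expected step is a step that the limit leaves unreadable from compound 1 to compound 4. Compound 4 is expected to give 600000 nM, with a range from 300000 nM to 1500000 nM.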

Compound 4, half-maximal cytotoxic concentration: > 500000 nM
Compound 4: a limit, no number; the forecaster's own chance of this, stated with the estimate: 85%; the middle value lies beyond the limit too.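

No new step can be read between compound 4 and compound 1, compound 2 or compound 3 in this assay, because all four give the same limit and no number: the limit of > 500000 nM in this assay, at which 4 of the 4 values shown sit.

The compounds shown leave open how far these groups on the amide-type nitrogen differ in cytotoxicity.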